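Arylpiperazine ethylamide series: notes toward compound 4

This account rests on a few compounds, and the source may have more. Where it says the series, first, only, none or still open, it means among the compounds named here.

Three members of the series have numbers in a functional assay for antagonist activity at Adrenergic receptor alpha-1 (Rattus norvegicus); on this read-out higher numbers stand for weaker binding and lower numbers for tighter binding. Compound 1 `COc1ccc(Cl)cc1N1CCN(CCNC(=O)c2cccnc2)CC1` gives 2750 nM, compound 2 `COc1ccc(Cl)cc1N1CCN(CCNC(=O)c2cc3ccccc3oc2=O)CC1` gives 49 nM, and compound 3 `Cc1ccc(N2CCN(CCNC(=O)c3cccnc3)CC2)cc1` gives 295 nM. On these three numbers compound 3 stands second highest: its nearest neighbour is compound 2, whose number is lower by a margin beyond the scatter, and its furthest is compound 1, whose number is higher by a margin also beyond the scatter. Going by the values given here, no two of the measured compounds differ in a single place, so no step between measured compounds can be read off within this assay, and nothing in the data calibrates the exchange of one aromatic amide head for another.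

Compound 4 `Cc1ccc(N2CCN(CCNC(=O)c3ccco3)CC2)cc1` has not yet been measured. It differs from compound 3 in one place: furan-2-yl in place of pyridin-3-yl on a carbonyl carbon. Among the compounds with values here, with no measured pair to lean on, the step is expected to be modest, leaning toward a lower number but possibly none beyond the scatter. The estimate for compound 4 in this assay is 200 nM, within a range of 60 nM to 700 nM, which is an expected step of a 1.5-fold lower number from compound 3 to compound 4 (0.17 log units; within the scatter).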

Compound 4, dissociation constant: 339 nM
The estimate for compound 4 lay 1.7-fold (0.23 log units) below the measured number, and the stated range covers the measured number.
By their numbers in this assay, from the lowest: compound 2; then compounds 3 and 4 (each within the scatter of the next); then compound 1.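

In this assay, going by these compounds alone, a 1.1-fold higher number from compound 3 to compound 4 (0.06 log units; within the scatter) is the first step that can be read at a single place, and it comes from furan-2-yl in place of pyridin-3-yl on a carbonyl carbon. On the core of compound 3, this position therefore takes a five-membered aromatic ring in place of a six-membered one, and oxygen in place of nitrogen as the ring hetero atom, with no shift beyond the scatter. No available measurement bears on why the two heads read alike.

On these data alone, whether the same exchange also reads alike on the core of compound 1 remains open, as a flat step on one core does not carry over to another. Also open, as far as these compounds go, is how far this tolerance extends on the same carbonyl carbon, for instance to a plain phenyl, to a saturated amine such as piperidin-4-yl, or to a furan-2-yl bearing a carboxylic acid.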